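A Sulfur Substituent Replaces Dimethylamino on Compound 1

A few compounds are considered here, and "the series" means these few. Any claim that something is new, unique, unknown or untested is made for them only; others in the source may bear on it.

In a functional assay on DU-145 cells (Homo sapiens) for inhibition, read by trypan blue exclusion, with a stated time of 96 h (a lower number here means a stronger inhibitor of growth, a higher number a weaker inhibitor of growth), compound 1 `CN(C)c1ccc(/C=C(\C(=O)c2ccc(Br)cc2)S(=O)(=O)Cc2ccc(F)cc2)cc1` gives 50000 nM, level with compound 3 `Cc1ccc(S(=O)(=O)/C(=C/c2ccc(N(C)C)cc2)C(=O)c2ccc(Br)cc2)cc1` at 50000 nM; together these are the highest of the three numbers, while compound 2 `Cc1ccc(S/C(=C/c2ccc(Oc3ccccc3)cc2)C(=O)c2ccc(Cl)cc2)cc1` sits apart at 10000 nM. Compound 4 `CSc1ccc(/C=C(\C(=O)c2ccc(Br)cc2)S(=O)(=O)Cc2ccc(F)cc2)cc1` differs from compound 1 by methylsulfanyl in place of dimethylamino on an aromatic carbon. Within the data shown here, the only single-point step on record, no change at the digits printed from compound 1 to compound 3 (within the scatter), concerns the sulfonyl sulfur rather than the aromatic carbon, and compound 2 differs from compound 1 in several places at once, so no measured step bears directly on this change. With nothing in the data to argue for a gain, the expected step is a 1.3-fold lower number from compound 1 to compound 4 (0.10 log units; within the scatter). Compound 4 is therefore estimated at 40000 nM, with a range from 15000 nM to 100000 nM.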

Compound 4, concentration for 50% growth inhibition: 50000 nM
Compound 4: the middle estimate sits 1.3-fold (0.10 log units) below what was measured; the range from low to high includes it.
By their numbers in this assay, from the lowest: compound 2; then compounds 1, 3 and 4 (each within the scatter of the next).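

Exchanging dimethylamino for methylsulfanyl on this aromatic carbon in this assay gives no change at the digits printed from compound 1 to compound 4 (within the scatter), the first reading at this position among these compounds. Together with the step on the sulfonyl sulfur, no change at the digits printed from compound 1 to compound 3 (within the scatter), it makes a second single change that leaves the number in place, now at a different point of the molecule. No measured evidence accounts for this result.

Both groups compared here carry no ring and no net charge. As far as these compounds go, whether a carboxylic acid or a longer alkyl chain on this aromatic carbon would move the number remains open.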